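A few compounds are considered here, and "the series" means these few. Any claim that something is new, unique, unknown or untested is made for them only; others in the source may bear on it.

Compound 1 `O=C(NCCCCc1ccccc1)c1cccc(C2SCC(=O)N2c2cccc(-c3c[nH]nn3)c2)c1` is the starting point. Among the compounds with values here, in a functional assay on HOS-TE85 cells (Homo sapiens) for inhibition, read by CCK-8 assay, with a stated time of 72 h (on this read-out higher numbers stand for weaker inhibition and lower numbers for stronger inhibition), compound 1 gives 110 nM, which is the only number obtained so far in this study. Compound 2 `O=C(NCCCCn1cccn1)c1cccc(C2SCC(=O)N2c2cccnc2)c1` is the other compound already tested. In this assay compound 2 reaches only the limit > 1000 nM, so for it no number is known. Compound 2 differs from compound 1 in several places at once, so the pair shows only what the two values say and no single step can be read from it. Compound 3 `O=C(NCCCCc1ccccc1)c1cccc(C2SCC(=O)N2c2ccccc2)c1` has not yet been measured. It differs from compound 1 by hydrogen in place of 1H-1,2,3-triazol-4-yl on an aromatic carbon. Within the data shown here, with no step of this kind measured, the size of the change can only be guessed: compound 3 is expected to land at 300 nM, somewhere between 100 nM and 1500 nM, which would mean a step of a 2.7-fold higher number from compound 1 to compound 3 (0.44 log units; beyond the scatter) in this assay.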

Compound 3, half-maximal inhibitory concentration: 15.9 nM
The estimate for compound 3 lay 19-fold (1.28 log units) above the measured number; the measured number lies below the stated range.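

Replacing the 1H-1,2,3-triazol-4-yl group with hydrogen gives a 6.9-fold lower number from compound 1 to compound 3 (0.84 log units; beyond the scatter) in this assay and so shows that this group is not needed for inhibition in this pair. At this place on the six-membered aromatic ring of carbon only, the bare ring carbon with its hydrogen does better than the triazole, a direction that the two earlier compounds could not reveal because they differ in several places at once. No measurement shown here explains why the step runs this way.

The compounds shown leave open whether a small group at the same place, such as a fluorine atom, a hydroxyl or an amine, would match hydrogen or weaken inhibition. They also leave open whether the same swap would give a step of similar size on a compound with a different amide side chain, such as a shorter alkyl chain.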